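Swapping a Chloro for a Nitro Group

The source may report more compounds than this note shows. Statements on the series, on what has been measured and on what is new or still open speak of the compounds shown alone.

Three esters of a shared core have been measured so far. Compound 1 `Cc1ccc(C(=O)OC2CCN(C)CC2)cc1F`, compound 2 `CN1CCC(OC(=O)c2ccc(Cl)cc2)CC1` and compound 3 `CN1CCC(OC(=O)c2ccccc2Cc2ccccc2)CC1` were all tested in a functional assay on the whole organism with Mus musculus as the target; on this read-out lower numbers stand for lower potency and higher numbers for higher potency (the scale is a negative logarithm). In this assay compound 1 gives 1.32, compound 2 gives 1.11 and compound 3 gives 1.28. The three numbers sit close together; compound 2 holds the lowest of them, but compound 3 and compound 1 both lie within the usual scatter of repeated measurements, so none of the three can be called more or less potent than another on this evidence.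

Compound 4 `CN1CCC(OC(=O)c2ccc([N+](=O)[O-])cc2)CC1` has not yet been measured. It differs from compound 2 in one place: nitro in place of chloro on an aromatic carbon.

Within the data shown here, no step between two measured compounds covers this kind of exchange, so there is nothing to lean on except the narrow spread of the three known values. The step from compound 2 to compound 4 is therefore expected to be small, in no clear direction, and to stay within the scatter: a number 0.09 log units higher from compound 2 to compound 4 (within the scatter). On that basis compound 4 is estimated to give about 1.2 in this assay, with a likely range from 0.8 to 1.6.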

Compound 4, logarithm of the reciprocal of the active concentration, log(1/C): 1.14
Estimate against measurement, compound 4: 0.06 log units above; measured number inside the range.
By their numbers in this assay, from the lowest: compounds 2, 4, 3 and 1 (each within the scatter of the next).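

Among these compounds, this is the first direct comparison at this position, on an aromatic carbon para to a large group. In this assay the exchange of chloro for nitro gives a number 0.03 log units higher from compound 2 to compound 4 (within the scatter) and so does not separate the two groups. The size of the entering group also makes this informative: nitro brings 3 heavy atoms and 2 hydrogen-bond acceptors where chloro had 1 heavy atom and 0 hydrogen-bond acceptors, yet the number stays within the scatter, so at least this one difference in size and acceptor count leaves no readable mark on the result. Nothing measured here offers an explanation for how closely the two compounds agree.

The compounds shown leave open whether an amine, a carboxylic acid or a longer chain at this position would give a step beyond the scatter, or whether this position tolerates nearly any group. They also leave open whether nitro and chloro would still read alike in any test other than this assay.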